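Trifluoromethyl in place of fluoro on the aryl ring

The compounds below may be only part of what the source reports. "The series", "measured", "known", "first", "only" and "open" are said of these compounds alone.

Measured in a functional assay on CHO-K1 cells for antagonist activity at adenosine receptor A1 (Homo sapiens), read by a beta-galactosidase reporter and cAMP accumulation, with stated times of 15 min and 6 h; a lower number here means a stronger inhibitor, a higher number a weaker inhibitor:
compound 1, `Nc1nc(-c2ccccc2)nc2sc(Cc3ccccc3)cc12`, 151 nM
compound 2, `N#Cc1cccc(-c2nc(N)c3cc(Cc4ccccc4)sc3n2)c1`, 222 nM
compound 3, `Nc1nc(-c2cccc(F)c2)nc2sc(Cc3ccccc3)cc12`, 123 nM

Compound 3 has the lowest number of the three, but it is not set apart: the step of a 1.2-fold lower number from compound 1 to compound 3 (0.09 log units; within the scatter) and the step of a 1.8-fold lower number from compound 2 to compound 3 (0.26 log units; within the scatter) both lie inside the scatter, so the three compounds cannot be told apart in this assay.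

Compound 4, `Nc1nc(-c2cccc(C(F)(F)F)c2)nc2sc(Cc3ccccc3)cc12`, differs from compound 3 in one place: trifluoromethyl in place of fluoro on an aromatic carbon. Going by the values given here, the change sits on the same aromatic carbon that carries fluoro in compound 3 and cyano in compound 2, so the steps that bear on it are those at that carbon: a 1.5-fold higher number from compound 1 to compound 2 (0.17 log units; within the scatter), a 1.2-fold lower number from compound 1 to compound 3 (0.09 log units; within the scatter) and a 1.8-fold lower number from compound 2 to compound 3 (0.26 log units; within the scatter). Each of them is within the scatter, so hydrogen, fluoro and cyano at this carbon give indistinguishable numbers in this assay. Among the compounds with values here, nothing among the measured compounds shows that a fourth group at this carbon should behave differently, so no step beyond the scatter is expected in either direction.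

Compound 4 is therefore estimated at 140 nM, with a range from 60 nM to 330 nM. This estimate means an expected 1.1-fold higher number from compound 3 to compound 4 (0.06 log units; within the scatter).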

Compound 4, inhibition constant: > 1000 nM
Compound 4: only a limit was reported (the forecaster's own chance of this, stated with the estimate: 3%); at least 7.1-fold (0.85 log units) between middle value and limit.
By their numbers in this assay, from the lowest: compounds 3, 1 and 2 (each within the scatter of the next). At a limit, above all of these: compound 4.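

In this assay, the aromatic carbon meta to a large group proves not to be indifferent to what it carries: trifluoromethyl gives an at least 8.1-fold higher number from compound 3 to compound 4 (0.91 log units; beyond the scatter), as well as an at least 4.5-fold higher number from compound 2 to compound 4 (0.65 log units; beyond the scatter) and an at least 6.6-fold higher number from compound 1 to compound 4 (0.82 log units; beyond the scatter). Hydrogen, fluoro and cyano at this carbon could not be told apart, so the apparent tolerance seen with compound 1, compound 2 and compound 3 does not extend to every group, and fluoro with 1 heavy atom giving way to trifluoromethyl with 4 heavy atoms is the first change here to move the number beyond the scatter. Compound 4 carries a limit and not a number, so all three steps fix only a minimum size: the limit of > 1000 nM in this assay, at which 1 of the 4 values shown sits.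

What sets trifluoromethyl apart from fluoro and cyano at this carbon stays open, and the compounds shown offer no way to assign a cause. Also open, from the compounds shown here alone, is whether a methyl, a methoxy or an amine at this carbon would match hydrogen, fluoro and cyano or go the way of trifluoromethyl, and whether trifluoromethyl at another carbon of this ring would have the same result.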